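The compounds below may be only part of what the source reports. "The series", "measured", "known", "first", "only" and "open" are said of these compounds alone.

In a functional assay on MCF7 cells (Homo sapiens) for antiproliferative activity, read by MTT assay, with a stated time of 48 h (a higher number here means a weaker inhibitor, a lower number a stronger inhibitor), compound 1 `COc1cccc(-c2nn(-c3ccccc3)cc2C(Nc2nc3ccccc3s2)c2c(O)ccc3ccccc23)c1` gives 16900 nM. Its neighbours are compound 2 `Cc1cccc(-c2nn(-c3ccccc3)cc2C(Nc2nc3ccccc3s2)c2c(O)ccc3ccccc23)c1` at 17300 nM and compound 3 `Cc1ccc(-c2nn(-c3ccccc3)cc2C(Nc2nc3ccccc3s2)c2c(O)ccc3ccccc23)cc1` at 13100 nM, and all three lie within the scatter of one another. The unmeasured compound 4 `COc1cccc(-c2nn(-c3ccccc3)cc2C(Nc2nc3ccc(Cl)cc3s2)c2c(O)ccc3ccccc23)c1` differs from compound 1 by chloro in place of hydrogen on an aromatic carbon, which turns 1,3-benzothiazol-2-yl into 6-chloro-1,3-benzothiazol-2-yl. The measured steps are a 1.0-fold higher number from compound 1 to compound 2 (0.01 log units; within the scatter), a 1.3-fold lower number from compound 1 to compound 3 (0.11 log units; within the scatter) and a 1.3-fold lower number from compound 2 to compound 3 (0.12 log units; within the scatter). All are within the scatter, but each alters only the methoxy- or methyl-bearing phenyl group, so none tests this position. No step beyond the scatter is therefore expected in this assay. The expected step is a 1.3-fold lower number from compound 1 to compound 4 (0.11 log units; within the scatter). Compound 4 is estimated at 13000 nM, with a range of 6000 nM to 26000 nM.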

Compound 4, half-maximal inhibitory concentration: 36000 nM
The estimate for compound 4 lay 2.8-fold (0.44 log units) below the measured number; the whole stated range lies below it.
By their numbers in this assay, from the lowest: compounds 3, 1 and 2 (each within the scatter of the next); then compound 4.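

Going by these compounds alone, the earlier steps altered only the phenyl group, so this is the first reading of the 1,3-benzothiazol-2-yl group. In this assay, chloro in place of hydrogen there gives a 2.1-fold higher number from compound 1 to compound 4 (0.33 log units; beyond the scatter) and so a weaker inhibitor, a modest step but beyond the scatter. This position therefore responds to substitution, unlike the phenyl changes so far, and no measurement available here explains the shift.

As far as these compounds go, whether a fluoro, methoxy or amine at this place would also weaken inhibition remains open. So does whether chloro would have the same effect on compound 2 or compound 3.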